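Compound 3: a new group on the carbonyl carbon

The compounds below may be only part of what the source reports. "The series", "measured", "known", "first", "only" and "open" are said of these compounds alone.

In an ADME assay on HEK293 cells (Homo sapiens) for cytotoxicity, read by MTT assay, with a stated time of 36 h (on this read-out lower numbers stand for stronger inhibition and higher numbers for weaker inhibition), compound 1 (`O=C(c1ccc2c(c1)OCCO2)C1CCN(Cc2coc(-c3ccc(F)cc3)n2)CC1`) gives no number, only a limit of > 150 ug/mL. Compound 2 (`Cc1ccc(-c2nc(CN3CCC(C(=O)c4ccc5c(c4)OCCO5)CC3)co2)cc1`) is likewise known only by a limit, > 150 ug/mL. The record so far is therefore (the limit of > 150 ug/mL in this assay, at which 2 of the 2 values shown sit).

Compound 3 (`O=C(c1ccc(F)c(F)c1)C1CCN(Cc2coc(-c3ccc(F)cc3)n2)CC1`) departs from compound 1 at one place: 3,4-difluorophenyl in place of 2,3-dihydro-1,4-benzodioxin-6-yl on a carbonyl carbon. In words, 3,4-difluorophenyl stands in place of 2,3-dihydro-1,4-benzodioxin-6-yl on a carbonyl carbon.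

For the measured compounds named here, only one measured step is available, a step that the two limits leave unreadable from compound 1 to compound 2. It puts methyl in place of fluoro on an aromatic carbon, so it does not touch the group exchanged here, and it has no readable size. Going by the values given here, no measured step therefore shows what this exchange does, and no shift in either direction can be predicted in this assay. The expected change is none beyond the scatter, a number no higher from compound 1 to compound 3 (the limit leaves the size open). Compound 3 is estimated at 150 ug/mL, with an expected range from 70 ug/mL to 300 ug/mL, and it may well be reported only as a limit.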

Compound 3, half-maximal inhibitory concentration: > 150 ug/mL
Compound 3 gave a limit, no number; the forecaster's own chance of this, stated with the estimate: 65%; the middle value lies on the limit itself.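

For the compounds shown here, compound 3, like compound 1, is known in this assay only by a limit, so the step between them cannot be read and the result adds no new readable step. The compounds shown leave open how far each lies from that limit, and whether either exchange changes the read-out at all: the limit of > 150 ug/mL in this assay, at which 3 of the 3 values shown sit.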